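A few compounds are considered here, and "the series" means these few. Any claim that something is new, unique, unknown or untested is made for them only; others in the source may bear on it.

Measured so far in a functional assay on the whole organism (stomach) for inhibition, with Rattus norvegicus as the target, at a dose of 100 mg/kg by the intraduodenal route; a lower number here means less inhibition, a higher number more inhibition at the dose given (going by the name of the read-out):
- compound 1, `N=C(S)CCN1N=C(c2ccc(Cl)c(Cl)c2)CCC1=O`: 47.2%
- compound 2, `N=C(S)CCCCCCN1N=C(c2ccccc2)CCC1=O`: 68.3%
- compound 3, `Cc1cc(-c2ccccc2)nn(CCC(=N)S)c1=O`: 60.2%

In this assay compound 1 stands lowest of the three numbers. Compound 3 lies above compound 1 by a margin beyond the scatter, and compound 2 lies above compound 1 by a larger margin, also beyond the scatter. Compound 4, `N=C(S)CCN1N=C(c2ccc(Cl)cc2)CCC1=O`, differs from compound 1 in one place: hydrogen in place of chloro on an aromatic carbon. For the measured compounds named here, no pair of measured compounds isolates a change of this kind, so nothing measured here shows what the loss of one chloro does; the expectation rests on the value of compound 1 alone. The step of a number 5.2 percentage points lower from compound 1 to compound 4 (within the scatter) is expected to be small, if present at all, and not clearly beyond the scatter. Compound 4 is estimated at 42%, with a range from 25% to 60%.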

Compound 4, a percentage reported as inhibition, in the whole organism at one dose (the size of the read-out at that dose, not a potency): 43.1%
Compound 4: middle estimate off by 1.1 percentage points, on the low side; measured number inside the range.
By their numbers in this assay, from the lowest: compounds 4 and 1 (each within the scatter of the next); then compounds 3 and 2 (each within the scatter of the next).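

In this assay the series gains its first one-place step (a number 4.1 percentage points lower from compound 1 to compound 4 (within the scatter)): hydrogen in place of chloro on an aromatic carbon. Compound 1 and compound 4 cannot be told apart here, so this chloro is not required for the inhibition seen at this dose. No measurement on hand bears on the reason.

Open, on these data alone, is whether a methoxy group, an amine or a carboxylic acid on this aromatic carbon would separate from compound 4, and what loss of the remaining chloro does. As far as these compounds go, the effect of a longer chain on the core of compound 4 is also open.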